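A Second Methoxy on Compound 3

The source may report more compounds than this note shows. Statements on the series, on what has been measured and on what is new or still open speak of the compounds shown alone.

In a functional assay on HeLa cells (Homo sapiens) for cytotoxicity, read by MTT assay, with a stated time of 48 h (on this read-out higher numbers stand for weaker inhibition and lower numbers for stronger inhibition), compound 1 (`COc1ccc(/C=C/C(=O)/C=C/c2cc3ccccc3nc2Cl)cc1`) gives > 10000 nM as a limit of the assay and not a number. Compound 2 (`COc1ccc(/C=C/C(=O)/C=C/c2cc3ccccc3nc2Cl)c(OC)c1`) gives > 10000 nM as a limit too. Compound 3 (`COc1ccc(/C=C/C(=O)/C=C/c2cc3ccccc3nc2Oc2ccccc2)cc1`) gives > 10000 nM as a limit as well, so it has no exact place on the scale. All three compounds sit at the limit of > 10000 nM in this assay, at which 3 of the 3 values shown sit, and none can be ranked against another.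

Compound 4 (`COc1ccc(/C=C/C(=O)/C=C/c2cc3ccccc3nc2Oc2ccccc2)c(OC)c1`) differs from compound 3 by one change: methoxy in place of hydrogen on an aromatic carbon (methoxy in place of hydrogen on an aromatic carbon, 4-methoxyphenyl to 2,4-dimethoxyphenyl). The same replacement is seen in a step that the two limits leave unreadable from compound 1 to compound 2 and gives no size to carry over. The exchange of chloro for phenoxy, a step that the two limits leave unreadable from compound 1 to compound 3 in the same assay, gives none either.

With no readable step to draw on, the expected outcome is a step that the limit leaves unreadable from compound 3 to compound 4 and no step beyond the scatter is foreseen in this assay for this change. Compound 4 is estimated at 15000 nM with an expected range from 8000 nM to 30000 nM and a report as a bare limit is the likeliest result.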

Compound 4, half-maximal inhibitory concentration: > 10000 nM
Compound 4 was reported as a limit (the forecaster's own chance of this, stated with the estimate: 85%); the middle value lies beyond the limit too.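

Compound 4 is reported only as a limit, so no size can be read for its steps from compound 2 or compound 3: the limit of > 10000 nM in this assay, at which 4 of the 4 values shown sit.

Going by these compounds, whether methoxy in place of hydrogen or phenoxy in place of chloro shifts potency in this assay stays open, with none of the four compounds holding an exact place on the scale.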